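This account rests on a few compounds, and the source may have more. Where it says the series, first, only, none or still open, it means among the compounds named here.

Measured so far:
- Compound 1 `O=C(Nc1cccc(Nc2ncc(F)c(Nc3ccc(F)cc3)n2)c1)c1cccc([N+](=O)[O-])c1`: 11400 nM
- Compound 2 `CN1CCC(C(=O)Nc2cccc(Nc3ncc(F)c(Nc4ccc(F)cc4)n3)c2)CC1`: 11900 nM

In a functional assay on KBVIN cells (Homo sapiens) for antiproliferative activity, read by sulforhodamine B assay, with a stated time of 3 days (on this read-out higher numbers stand for weaker inhibition of growth and lower numbers for stronger inhibition of growth), compound 2 gives 11900 nM, and with compound 1 at 11400 nM, the two numbers lie within the usual scatter of each other. Compound 3 `CN(C)c1ccc(C(=O)Nc2cccc(Nc3ncc(F)c(Nc4ccc(F)cc4)n3)c2)cc1`, not yet measured, carries 4-(dimethylamino)phenyl in place of 1-methylpiperidin-4-yl on a carbonyl carbon.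

Among the measured compounds shown here, only one measured step bears on this place. It is a 1.0-fold higher number from compound 1 to compound 2 (0.02 log units; within the scatter), with 1-methylpiperidin-4-yl in place of 3-nitrophenyl on the same carbonyl carbon, and it stays within the scatter. One step is thin evidence, but it gives no reason to expect a real shift in this assay in either direction. The expected change is a 1.2-fold lower number from compound 2 to compound 3 (0.08 log units; within the scatter), which would not go beyond the scatter. For compound 3 the estimated value is 10000 nM, with an expected range of 3500 nM to 25000 nM.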

Compound 3, concentration for 50% growth inhibition: > 10000 nM
Compound 3 gave a limit, no number; the forecaster's own chance of this, stated with the estimate: 15%; the middle value lies on the limit itself.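

In this assay compound 3 gives > 10000 nM, which is a limit and not a number. The steps to compound 3 from compound 1 and from compound 2 therefore cannot be read. The compounds shown leave open whether 4-(dimethylamino)phenyl on the carbonyl carbon really changes growth inhibition, and by how much.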